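The source may hold more compounds than are shown below. What is called first, only, known or untested is meant among the compounds shown, and "the series" means these compounds.

Notes on a sulfonyl series. Compound 1 `O=C(NCc1ccc(Cl)nc1)Nc1ccc(S(=O)(=O)c2ccccc2)cc1` sets the lower of the two numbers available: in an assay on isolated protein for inhibition of Nicotinamide phosphoribosyltransferase (Homo sapiens), read by spectrophotometry, with stated times of 15 min and 30 min (on this read-out higher numbers stand for weaker inhibition and lower numbers for stronger inhibition), compound 1 gives 13 nM. Compound 2 `C[C@@H]1COC[C@@H](C)N1S(=O)(=O)c1ccc(NC(=O)NCc2cccnc2)cc1` stands at the higher of the two; in this assay compound 2 gives 52 nM, a gap to compound 1 that lies beyond the usual scatter. Among the compounds with values here, the two compounds differ in more than one place, so no single step between them is resolved, and the gap says only what the two values show.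

The next compound extends from compound 2. Compound 3 `N[C@H]1CC[C@H](NS(=O)(=O)c2ccc(NC(=O)NCc3cccnc3)cc2)CC1` carries (4-aminocyclohexyl)amino in place of 3,5-dimethylmorpholin-4-yl on a sulfonyl sulfur. Within the data shown here, no measured pair in the set isolates a change of this kind, so the direction of any step rests on nothing more than the shared core kept intact. The change is treated as neutral within the scatter, with the number for compound 3 expected close to that of compound 2. The step of a 1.0-fold lower number from compound 2 to compound 3 (0.02 log units; within the scatter) is estimated as small and of uncertain sign. Compound 3 is accordingly estimated at 50 nM, with a range from 15 nM to 170 nM.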

Compound 3, half-maximal inhibitory concentration: 4 nM
Beside the measured number, compound 3's estimate is 13-fold (1.10 log units) above it, and the stated range ends above it.
By their numbers in this assay, from the lowest: compound 3; then compound 1; then compound 2.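

In this assay the group on a sulfonyl sulfur is the one place in the series where a single change can be read, and (4-aminocyclohexyl)amino in place of 3,5-dimethylmorpholin-4-yl gives a 13-fold lower number from compound 2 to compound 3 (1.11 log units; beyond the scatter) with the shared core kept intact, so this position is not indifferent to the group it carries. The two groups match in heavy-atom count, in having one six-membered non-aromatic ring, in net charge and in defined stereocentres, yet they differ in the ring, which has 2 hetero atoms in the leaving group and carbon only in the entering one, and in hydrogen-bond donors, with 0 in the leaving group and 2 in the entering one. No measurement bears on which of these differences carries the step, so the step stays a bare observation on a single pair.

The compounds shown do not separate the amino group on the cyclohexyl ring from the amino link to the sulfur, and a plain cyclohexylamino group or a 4-hydroxycyclohexylamino group would divide the two. As far as these compounds go, whether a step of this size also holds on another core, such as the core of compound 1, remains open.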